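This account rests on a few compounds, and the source may have more. Where it says the series, first, only, none or still open, it means among the compounds named here.

Compound 1 `CC1CCN(Cc2ccc3nc(NC(=O)N/N=C/c4cn(Cc5cccc(Cl)c5)c5ccccc45)sc3c2)CC1` gives 280 nM in a functional assay on NCI-H460 cells (Homo sapiens) for cytotoxicity, read by MTT assay, with a stated time of 72 h; a higher number here means a weaker inhibitor, a lower number a stronger inhibitor. Compound 2 `CN(C)Cc1ccc2nc(NC(=O)N/N=C/c3cn(Cc4ccccc4)c4ccccc34)sc2c1` gives 400 nM. Compound 3 `CCN(CC)Cc1ccc2nc(NC(=O)N/N=C/c3cn(Cc4ccccc4)c4ccccc34)sc2c1` gives 450 nM.

The three numbers sit close together. For the measured compounds named here, from compound 2 the only measured step is a 1.1-fold higher number from compound 2 to compound 3 (0.05 log units; within the scatter), and the values of compound 2 and compound 1 are likewise within the scatter of each other. Compound 4 `CN(C)Cc1ccc2nc(NC(=O)N/N=C/c3cn(Cc4ccc(C(C)(C)C)cc4)c4ccccc34)sc2c1` differs from compound 2 by tert-butyl in place of hydrogen on an aromatic carbon. Going by the values given here, no measured step touches that position: the one step on record changes the amine on the other side of the shared core, and it moves nothing beyond the scatter. With no sign that this ring steers the number, compound 4 is expected near compound 2, at 400 nM with a range of 150 nM to 1100 nM. The expected step is no change at the digits printed from compound 2 to compound 4 (within the scatter), within the scatter.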

Compound 4, half-maximal inhibitory concentration: 810 nM
For compound 4 the middle estimate is 2.0-fold (0.31 log units) below the measured one; the measured number falls inside the stated range.
By their numbers in this assay, from the lowest: compounds 1, 2, 3 and 4 (each within the scatter of the next, the first and the last beyond it).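

For the compounds shown here, the benzyl group on the shared core is the first place where a change goes beyond the scatter: 4-(tert-butyl)benzyl in place of benzyl gives a 2.0-fold higher number from compound 2 to compound 4 (0.31 log units; beyond the scatter) in this assay and so weakens the compound modestly. The amine change, by contrast, gave a 1.1-fold higher number from compound 2 to compound 3 (0.05 log units; within the scatter) and did not register. Nothing on hand explains this step.

On these data alone, it remains open whether methyl, methoxy or a carboxylic acid on this same aromatic carbon would shift the number too. As far as these compounds go, it is also open whether tert-butyl would act alike alongside diethylamino.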